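The source may hold more compounds than are shown below. What is called first, only, known or untested is meant among the compounds shown, and "the series" means these compounds.

Measured in a functional assay on MCF7 cells (Homo sapiens) for antiproliferative activity, read by MTT assay, with a stated time of 72 h; on this read-out lower numbers stand for stronger inhibition and higher numbers for weaker inhibition:
Compound 1 `O=C1COc2ccc(-c3cnc(Cl)c(NS(=O)(=O)c4ccc(F)cc4)c3)cc2N1C1CCCCC1`: > 40000 nM (a limit)
Compound 2 `COc1ncc(-c2ccc3c(c2)N(c2ccc(F)cc2)C(=O)CO3)cc1NS(=O)(=O)c1ccc(F)cc1`: > 40000 nM (a limit)
Compound 3 `COc1ncc(-c2ccc3c(c2)N(C2CCCCC2)C(=O)CO3)cc1NS(=O)(=O)c1ccc(F)cc1`: 30100 nM

Compound 1 has no exact number, only the limit > 40000 nM. It therefore stands at the limit of > 40000 nM in this assay, at which 2 of the 3 values shown sit.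

The step to compound 4 `Cc1ccc(N2C(=O)COc3ccc(-c4cnc(Cl)c(NS(=O)(=O)c5ccc(F)cc5)c4)cc32)cc1` replaces the group on the nitrogen: 4-methylphenyl in place of cyclohexyl on an amide-type nitrogen in a ring. In words, this is 4-methylphenyl in place of cyclohexyl on an amide-type nitrogen in a ring.

Going by the values given here, two measured steps bear on this change. The closer one acts at the same place, with cyclohexyl in place of 4-fluorophenyl: an at least 1.3-fold lower number from compound 2 to compound 3 (0.12 log units; that floor lies within the scatter). It runs from an aromatic group to cyclohexyl, the opposite way to the step now in question, and on a core carrying methoxy rather than chloro. The other step links the two core substituents, with methoxy in place of chloro: an at least 1.3-fold lower number from compound 1 to compound 3 (0.12 log units; that floor lies within the scatter). Both are floors only and neither goes beyond the scatter, so they set no firm size.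

Drawing on these steps, no change beyond the scatter is expected in this assay, and any shift would be expected toward higher numbers. Compound 4 will quite probably report a limit too. For compound 4 the expected value is 40000 nM, with an estimated range of 20000 nM to 80000 nM. The estimated step is a number no higher from compound 1 to compound 4 (the limit leaves the size open).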

Compound 4, half-maximal inhibitory concentration: 32600 nM
Beside the measured number, compound 4's estimate is 1.2-fold (0.09 log units) above it; the measured number falls inside the stated range.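

In this assay, placing 4-methylphenyl in place of cyclohexyl on the amide-type nitrogen in a ring of the chloro-bearing core gives an at least 1.2-fold lower number from compound 1 to compound 4 (0.08 log units; that floor lies within the scatter). Going by these compounds alone, compound 4 thus supplies the only exact value shown for a chloro-bearing compound and the only exact value shown for an aromatic group at this place, so a number can be read on this core with such a group on the nitrogen. Compound 1 remains a limit, and the step can be read only as a floor, with its true size unknown, because of that limit: the limit of > 40000 nM in this assay, at which 2 of the 4 values shown sit.

The compounds shown leave open whether any group on this nitrogen can move the number beyond the usual scatter, since the only exact values shown come from cyclohexyl on the methoxy-bearing core and 4-methylphenyl on the chloro-bearing core. A plain methyl, or a longer chain ending in an amine or a carboxylic acid, at this same place would test that question on the shared core.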